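Dimethylamino for phenyl on the sulfonyl sulfur of compound 3

The compounds below may be only part of what the source reports. "The series", "measured", "known", "first", "only" and "open" are said of these compounds alone.

In an ADME assay on the whole organism (Rattus norvegicus, strain Harlan-Han Wistar) for pharmacokinetics (a higher number here means faster removal of the compound, a lower number slower removal), compound 3 `Cc1ccc2[nH]c(C(=O)N[C@H]3CCN(S(=O)(=O)c4ccccc4)C[C@@H]3C(=O)NCCN(C)C)cc2c1` gives 57 mL/min/kg. Compound 1 `Cc1ccc2[nH]c(C(=O)N[C@H]3CN(S(=O)(=O)c4ccccc4)C[C@@H]3C(=O)NCCN(C)C)cc2c1` gives 79 mL/min/kg and compound 2 `Cc1ccc2[nH]c(C(=O)N[C@H]3CN(S(=O)(=O)c4cn(C)nc4C)C[C@@H]3C(=O)NCCN(C)C)cc2c1` gives 45 mL/min/kg, so compound 3 lies within the scatter of both. Compound 4 `Cc1ccc2[nH]c(C(=O)N[C@H]3CCN(S(=O)(=O)N(C)C)C[C@@H]3C(=O)NCCN(C)C)cc2c1` carries dimethylamino in place of phenyl on a sulfonyl sulfur, with dimethylamino in place of phenyl on a sulfonyl sulfur. Going by the values given here, one measured step bears on this place: a 1.8-fold lower number from compound 1 to compound 2 (0.24 log units; within the scatter), where 1,3-dimethyl-1H-pyrazol-4-yl replaces phenyl. That step stays within the scatter, and a different group enters there, so it is only a loose guide. No step beyond the scatter is expected in this assay. The expected step is a 1.3-fold lower number from compound 3 to compound 4 (0.10 log units; within the scatter). Compound 4 is estimated at 45 mL/min/kg, with an expected range of 25 mL/min/kg to 78 mL/min/kg.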

Compound 4, clearance: 40 mL/min/kg
Estimate against measurement, compound 4: 1.1-fold (0.05 log units) above; measured number inside the range.
By their numbers in this assay, from the lowest: compounds 4, 2, 3 and 1 (each within the scatter of the next).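

In this assay the sulfonyl sulfur also accepts a group without a ring: dimethylamino for phenyl gives a 1.4-fold lower number from compound 3 to compound 4 (0.15 log units; within the scatter). The earlier compounds shown here carried only the aromatic phenyl and 1,3-dimethyl-1H-pyrazol-4-yl here, so an aromatic ring at this place is not required to keep the number in this range. No measured data explain the step.

As far as these compounds go, whether a morpholine or a longer alkyl chain on the sulfonyl sulfur would give a step beyond the scatter remains open. So does whether dimethylamino gives a similar step on the core of compound 1.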